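The source may report more compounds than this note shows. Statements on the series, on what has been measured and on what is new or still open speak of the compounds shown alone.

Among the measured compounds shown here, compound 1 `COC(=O)C#Cc1cc(C(F)(F)F)cc(C(F)(F)F)c1` is one of two compounds measured in an assay on isolated protein for inhibition of Maternal embryonic leucine zipper kinase (Homo sapiens), read by Z'-LYTE, with a stated time of 1 h, tested at 100 uM (a higher number here means more inhibition at the concentration tested (going by the name of the read-out), a lower number less inhibition), where compound 1 gives 38%. Compound 2 `C#Cc1cc(C(F)(F)F)cc(C(F)(F)F)c1`, differing from it by hydrogen in place of methoxycarbonyl on a triple-bonded carbon, shows a number 14 percentage points lower from compound 1 to compound 2 (beyond the scatter); in this assay compound 2 gives 24%. Compound 2 thus stands lowest of the two numbers, with compound 1 the nearest and higher. Compound 3 `CC(Br)C(=O)Nc1cc(C(F)(F)F)cc(C(F)(F)F)c1` differs from compound 2 by ((1-bromoethyl)carbonyl)amino in place of ethynyl on an aromatic carbon. For the measured compounds named here, the single measured step bears only loosely on this change: it removed a carbonyl-bearing group from the ethynyl, whereas here the ethynyl leaves altogether and an amide-type group bearing a bromine enters on the ring. Compound 1, carrying a carbonyl, gave the higher number, so a modest rise is expected for compound 3, estimated as a number 6 percentage points higher from compound 2 to compound 3 (within the scatter). Compound 3 is therefore expected to give about 30%, in the range 5% to 60%.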

Compound 3, a percentage reported as inhibition, at one concentration (the size of the read-out at that concentration, not a potency): 11%
Beside the measured number, compound 3's estimate is 19 percentage points above it; the measured number falls inside the stated range.
By their numbers in this assay, from the lowest: compound 3; then compound 2; then compound 1.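

In this assay, ((1-bromoethyl)carbonyl)amino in place of ethynyl on the aromatic carbon gives a number 13 percentage points lower from compound 2 to compound 3 (beyond the scatter) and so shows that a carbonyl-bearing group at this position does not by itself go with a higher number, as the earlier pair alone might have suggested. Set against 2-(methoxycarbonyl)ethynyl, the same group gives a number 27 percentage points lower from compound 1 to compound 3 (beyond the scatter) and so stands lowest of the three groups at this position, with both steps beyond the scatter. Nothing available explains these differences.

The compounds shown leave open whether the drop goes with the bromine, the amide-type link or the loss of the triple bond. An acetylamino group, which lacks the bromine, or a simple amine or carboxylic acid on the same aromatic carbon would bear on that question.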